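Dropping the (4-Chlorophenyl)carbonyl Group: What to Expect

The source may report more compounds than this note shows. Statements on the series, on what has been measured and on what is new or still open speak of the compounds shown alone.

Compound 1, `O=C(Nc1cc(C(F)(F)F)cc(C(F)(F)F)c1)C1CCc2ccccc2N1C(=O)c1ccc(Cl)cc1`: 889 nM
Compound 2, `O=C(Nc1ccccc1C(F)(F)F)C1CCc2ccccc2N1`: 56800 nM

Both compounds were tested in a functional assay on NCI-H23 cells (Homo sapiens) for cytotoxicity, read by sulforhodamine B assay, with a stated time of 72 h; a lower number here means a stronger inhibitor of growth, a higher number a weaker inhibitor of growth. Compound 1 has the lowest number of the two; compound 2 lies far higher, well beyond the scatter. Compound 3, `O=C(Nc1cc(C(F)(F)F)cc(C(F)(F)F)c1)C1CCc2ccccc2N1`, has not yet been measured; it differs from compound 1 by hydrogen in place of (4-chlorophenyl)carbonyl on a nitrogen on an aromatic ring in a ring. Going by the values given here, no measured pair shows this change on its own, and compound 2 also carries a different substituted aryl, so its gap to compound 1 cannot be read as the effect of this change alone. For compound 3 the expected step is a 17-fold higher number from compound 1 to compound 3 (1.23 log units; beyond the scatter), a weakening beyond the scatter. Compound 3 is therefore estimated at 15000 nM, within a range from 3000 nM to 70000 nM.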

Compound 3, concentration for 50% growth inhibition: 8410 nM
Beside the measured number, compound 3's estimate is 1.8-fold (0.25 log units) above it, within the range that was stated.
By their numbers in this assay, from the lowest: compound 1; then compound 3; then compound 2.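

Going by these compounds alone, this is the first pair that differs only at this nitrogen, so the effect of the change can be read directly: hydrogen in place of (4-chlorophenyl)carbonyl gives a 9.5-fold higher number from compound 1 to compound 3 (0.98 log units; beyond the scatter) in this assay with the rest of the molecule unchanged. Growth inhibition at this position therefore depends on the group that leaves, though the data offer no measurement that accounts for this. The compounds shown leave open whether the chlorine, the aromatic ring or the carbonyl matters most; an acetyl or unsubstituted benzoyl group on this nitrogen would help separate them.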